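A Butylsulfanyl Replacement Tested Against Cytotoxicity Limits

A few compounds are considered here, and "the series" means these few. Any claim that something is new, unique, unknown or untested is made for them only; others in the source may bear on it.

The shared core of these compounds carries a variable group on one aromatic carbon. Compound 1 `Nc1nc(OCC(F)(F)F)c2ncn(/C=C3/CC3(CO)CO)c2n1` bears a 2,2,2-trifluoroethoxy group there. In an ADME assay on BCBL1 cells (Homo sapiens) for cytotoxicity, with a stated time of 7 days (a higher number here means that more compound is tolerated, a lower number that less compound is tolerated), compound 1 gives > 20000 nM, which is a limit of the assay and not a number. Among the compounds with values here, compound 2 `Nc1nc(NC2CC2)c2ncn(/C=C3/CC3(CO)CO)c2n1` carries cyclopropylamino, and in this assay compound 2 gives 71500 nM, the only number among the three measured compounds. Compound 3 `Nc1nc(NC2CCCCC2)c2ncn(/C=C3/CC3(CO)CO)c2n1` carries cyclohexylamino; in this assay compound 3 gives > 20000 nM, again a limit. The steps a step that the limit leaves unreadable from compound 1 to compound 2, a step that the two limits leave unreadable from compound 1 to compound 3 and a step that the limit leaves unreadable from compound 2 to compound 3 cannot be sized because of the limit of > 20000 nM in this assay, at which 2 of the 3 values shown sit. Compound 4 `CCCCSc1nc(N)nc2c1ncn2/C=C1/CC1(CO)CO` differs from compound 2 in one place: butylsulfanyl in place of cyclopropylamino on an aromatic carbon. Within the data shown here, none of the measured steps bears readably on this change, so no step beyond the scatter can be expected in either direction, and a limit rather than a number is quite possible. Compound 4 is accordingly estimated at 50000 nM, within a range from 20000 nM to 150000 nM. The expected step is a 1.4-fold lower number from compound 2 to compound 4 (0.16 log units; within the scatter).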

Compound 4, half-maximal cytotoxic concentration: > 20000 nM
Compound 4: a limit, no number; the forecaster's own chance of this, stated with the estimate: 60%; the middle value does not contradict the limit.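

Within the data shown here, compound 4 gives a limit and not a number, so no step linking it to compound 1, compound 2 or compound 3 can be read in this assay, because the values stop at a limit: the limit of > 20000 nM in this assay, at which 3 of the 4 values shown sit. The compounds shown leave open whether butylsulfanyl in place of cyclopropylamino shifts the half-maximal cytotoxic concentration at all, and in which direction.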